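Triazole aryl swap on two cores, cytotoxicity notes

The compounds below may be only part of what the source reports. "The series", "measured", "known", "first", "only" and "open" are said of these compounds alone.

Measured so far:
compound 1 `C=C1C(=O)[C@]23C[C@@]1(O)CC[C@H]2c1ccc(O)c(C)c1[C@@H]3Cn1cc(-c2ccccc2)nn1` — 1160 nM
compound 2 `C=C1C(=O)[C@]23C[C@@]1(O)CC[C@H]2c1ccc(O)c(C)c1[C@@H]3Cn1cc(-c2ccccn2)nn1` — 1570 nM
compound 3 `C=C1C[C@]23C[C@@]1(O)CC[C@@H]2c1cccc(C)c1[C@@H]3Cn1cc(-c2ccccn2)nn1` — > 20000 nM, a limit of the assay, not a number

All numbers come from a functional assay on A549 cells (Homo sapiens) for cytotoxicity, read by MTT assay, with a stated time of 4 days; a higher number here means a weaker inhibitor, a lower number a stronger inhibitor. Compound 1 and compound 2 share one core and differ only in phenyl in place of pyridin-2-yl on an aromatic carbon; the step is a 1.4-fold lower number from compound 2 to compound 1 (0.13 log units; within the scatter). Compound 3 carries a different core, and the difference between the two cores is not broken down here. For compound 3 the result is only a limit, > 20000 nM, which is the limit of > 20000 nM in this assay, at which 1 of the 3 values shown sits.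

Compound 4 `C=C1C[C@]23C[C@@]1(O)CC[C@@H]2c1cccc(C)c1[C@@H]3Cn1cc(-c2ccccc2)nn1` is not yet measured. It stands to compound 3 exactly as compound 1 stands to compound 2, with the same change at the same place: phenyl in place of pyridin-2-yl on an aromatic carbon. Because the measured step of a 1.4-fold lower number from compound 2 to compound 1 (0.13 log units; within the scatter) lies within the scatter, the step from compound 3 to compound 4 is expected to be small too, a step that the limit leaves unreadable from compound 3 to compound 4. Compound 3 shows only a limit, > 20000 nM. Compound 4 is therefore expected to stay at that limit as well, estimated at 25000 nM, between 8000 nM and 80000 nM.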

Compound 4, half-maximal inhibitory concentration: > 20000 nM
Compound 4 was reported as a limit; the forecaster's own chance of this, stated with the estimate: 70%; the middle value lies beyond the limit too.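

No step can be read from compound 3 to compound 4, since both results are limits and not numbers: the limit of > 20000 nM in this assay, at which 2 of the 4 values shown sit.

The compounds shown leave open how far beyond that limit compound 3 and compound 4 lie, and so whether phenyl in place of pyridin-2-yl makes any difference on their core.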